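The compounds below may be only part of what the source reports. "The series", "measured", "known", "first", "only" and "open" are said of these compounds alone.

Compound 1, `O=S(=O)(Nc1ccc(F)c(C#Cc2cnc3[nH]ncc3c2)c1F)c1cccnc1`, in a functional assay on HCT-116 cells (Homo sapiens) for antiproliferative activity, read by MTT assay, with a stated time of 68 h; a higher number here means a weaker inhibitor, a lower number a stronger inhibitor: > 10000 nM, a limit of the assay.
Compound 2, `O=S(=O)(Nc1ccc(F)c(C#Cc2cnc3[nH]nc(-c4ccccc4)c3c2)c1F)c1cccnc1`, in this assay: > 10000 nM, a limit of the assay.
Compound 3, `O=S(=O)(Nc1ccc(F)c(C#Cc2cnc3[nH]nc(-c4ccccc4Cl)c3c2)c1F)c1cccnc1`, in this assay: > 10000 nM, a limit of the assay.

Compound 3 thus stands at the top of what the assay reports, and the two other values shown sit there with it, as the limit of > 10000 nM in this assay, at which 3 of the 3 values shown sit, records. Among the compounds with values here, no measured compound gives a number in this assay; every value is a limit.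

Compound 4, `O=S(=O)(Nc1ccc(F)c(C#Cc2cnc3[nH]nc(-c4ccc(F)cc4)c3c2)c1F)c1cccnc1`, differs from compound 3 in one place: 4-fluorophenyl in place of 2-chlorophenyl on an aromatic carbon. The measured steps that bear on this change all concern the same aromatic carbon of the shared core. The step that the two limits leave unreadable from compound 1 to compound 3, the step that the two limits leave unreadable from compound 2 to compound 3 and the step that the two limits leave unreadable from compound 1 to compound 2 are each left unreadable, since both ends of every pair rest at the limit. Nothing in the data shows a readable step of any size or direction, and nothing shows whether a substituent on that carbon moves the value at all.

Compound 4 is therefore expected to stay where its three neighbours sit, so the step that the limit leaves unreadable from compound 3 to compound 4 is estimated as no readable change. For compound 4 the estimated value in this assay is 15000 nM, with a range from 5000 nM to 60000 nM, and most likely the assay again reports only a limit.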

Compound 4, half-maximal inhibitory concentration: > 10000 nM
Compound 4 gave a limit, no number (the forecaster's own chance of this, stated with the estimate: 85%); the middle value is on the limit's open side.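

In this assay compound 4 gives > 10000 nM, a limit of the assay and not a number. Within the data shown here, no step from compound 1, compound 2 or compound 3 to compound 4 can be read, because all four compounds rest at the same limit: the limit of > 10000 nM in this assay, at which 4 of the 4 values shown sit. The compounds shown leave open whether any substituent on that aromatic carbon moves the value at all.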